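Replacing the sulfur-linked ring on the amide chain of compound 3

The compounds below may be only part of what the source reports. "The series", "measured", "known", "first", "only" and "open" are said of these compounds alone.

Measured compounds in a functional assay on HT-29 cells (Homo sapiens) for cytotoxicity, read by MTT assay, with a stated time of 24 h, tested at 16 ug/mL; on this read-out lower numbers stand for a weaker effect and higher numbers for a stronger effect at the one concentration tested:
- Compound 1 `Cn1c(-c2ccc(NC(=O)CSc3nc4ccccc4o3)cc2)nc(-c2ccccc2)c1-c1ccccc1`: 56.2%
- Compound 2 `Cc1nnc(SCC(=O)Nc2ccc(-c3nc(-c4ccccc4)c(-c4ccccc4)n3C)cc2)s1`: 83.3%
- Compound 3 `Cn1c(-c2ccc(NC(=O)CSC3=NCCS3)cc2)nc(-c2ccccc2)c1-c1ccccc1`: 43.3%

Compound 3 gives the lowest of the three numbers in this assay, sitting a number 12.9 percentage points lower from compound 1 to compound 3 (beyond the scatter) and a number 40 percentage points lower from compound 2 to compound 3 (beyond the scatter). The next compound, compound 4 `CN1CCN(CC(=O)Nc2ccc(-c3nc(-c4ccccc4)c(-c4ccccc4)n3C)cc2)CC1`, differs from compound 3 by the change (a group of 7 heavy atoms (5 carbon, 2 nitrogen; one six-membered non-aromatic ring with 2 hetero atoms) in place of a group of 6 heavy atoms (3 carbon, 1 nitrogen, 2 sulfur; one five-membered non-aromatic ring with 2 hetero atoms), on a saturated chain carbon bound to a carbonyl carbon). The earlier steps shown here all exchanged the group attached to the sulfur while keeping the sulfur in place: a number 27.1 percentage points higher from compound 1 to compound 2 (beyond the scatter), a number 12.9 percentage points lower from compound 1 to compound 3 (beyond the scatter) and a number 40 percentage points lower from compound 2 to compound 3 (beyond the scatter). None of them removed the sulfur-bearing group as a whole, so they bear on the new step only loosely, showing that the group at this end of the chain can move the read-out by a modest to large amount in either direction. Compound 4 is expected to give about 48%, with a range from 25% to 72%. This estimate means an expected step of a number 4.7 percentage points higher from compound 3 to compound 4 (within the scatter), upward but with little confidence in direction.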

Compound 4, a percentage reported as activity, at one concentration (the size of the read-out at that concentration, not a potency): 33.7%
Compound 4: middle estimate off by 14.3 percentage points, on the high side, and the stated range covers the measured number.
By their numbers in this assay, from the lowest: compounds 4 and 3 (each within the scatter of the next); then compound 1; then compound 2.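

Compound 4 is the only compound shown in which no sulfur links the end group to the chain, as 4-methylpiperazin-1-yl sits directly on the saturated chain carbon bound to a carbonyl carbon, and in this assay this exchange gives a number 9.6 percentage points lower from compound 3 to compound 4 (within the scatter). The same position therefore tolerates a group without sulfur at the level of the non-aromatic ring of compound 3, whereas the comparisons with the aromatic sulfur-linked groups give a number 49.6 percentage points lower from compound 2 to compound 4 (beyond the scatter) and a number 22.5 percentage points lower from compound 1 to compound 4 (beyond the scatter). Nothing measured here accounts for these differences.

The compounds shown leave open whether the sulfur link itself matters, or only the group it carries, since 4-methylpiperazin-1-yl differs from those groups in more than that link. A morpholin-4-yl group or a simple dimethylamino group on the same chain carbon would show whether any group without sulfur can approach compound 2.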